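A chlorine moves on the fluorophenyl group

The source may hold more compounds than are shown below. What is called first, only, known or untested is meant among the compounds shown, and "the series" means these compounds.

In an ADME assay on Vero cells (Chlorocebus sabaeus) for cytotoxicity, read by MTT assay, with a stated time of 72 h (on this read-out lower numbers stand for higher toxicity in this test and higher numbers for lower toxicity in this test), compound 1 `C[C@]1(CN2CCc3nc(C4CCCCC4)ccc3C2)Cn2cc([N+](=O)[O-])nc2O1` has the entry "not determined" (no result reported). Compound 2 `C[C@]1(CN2CCc3nc(-c4cccc(Cl)c4F)ccc3C2)Cn2cc([N+](=O)[O-])nc2O1` gives > 32 ug/mL, which is a limit and not a number. Compound 3 `C[C@]1(CN2CCc3nc(-c4ccc(Cl)cc4F)ccc3C2)Cn2cc([N+](=O)[O-])nc2O1` gives > 32 ug/mL, again only a limit. Among the compounds with values here, the one measured step, a step that the two limits leave unreadable from compound 2 to compound 3, also swaps one chloro-fluorophenyl group for another. Compound 4 `C[C@]1(CN2CCc3nc(-c4cc(Cl)ccc4F)ccc3C2)Cn2cc([N+](=O)[O-])nc2O1` changes compound 3 once more in this group: 5-chloro-2-fluorophenyl in place of 4-chloro-2-fluorophenyl on an aromatic carbon. For compound 3 only a limit is known, and the nearest evidence is the limit of > 32 ug/mL in this assay, at which 2 of the 3 values shown sit. On that footing, no change beyond the usual scatter is expected in either direction, and the estimated step is a step that the limit leaves unreadable from compound 3 to compound 4. Compound 4 is estimated at 40 ug/mL, within an expected range of 20 ug/mL to 80 ug/mL, and will probably be reported as a limit too.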

Compound 4, half-maximal cytotoxic concentration: > 32 ug/mL
Compound 4 was reported as a limit; the forecaster's own chance of this, stated with the estimate: 85%; the middle value is on the limit's open side.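

Within the data shown here, compound 2, compound 3 and compound 4 each give only a limit in this assay, and no step among them can be read. As far as these compounds go, whether the chlorine's position matters in this assay remains open, with no exact value shown for any of the three.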